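Cytotoxicity of a trifluoromethyl analogue in HeLa cells

The source may report more compounds than this note shows. Statements on the series, on what has been measured and on what is new or still open speak of the compounds shown alone.

Within the data shown here, compound 2 `COc1cc(-c2noc(C(F)(F)F)n2)ccc1OCCCc1cc(C(=O)N(C)C)no1` is the only compound with a number in an ADME assay on HeLa cells (Homo sapiens) for cytotoxicity, read by crystal violet staining, with a stated time of 72 h; on this read-out higher numbers stand for lower toxicity in this test and lower numbers for higher toxicity in this test: there compound 2 gives 68000 nM. Compound 1 `CCOC(=O)c1cc(CCCOc2ccc(-c3noc(C(F)(F)F)n3)cc2OC)on1` differs from it only at the carbonyl carbon. In this assay compound 1 reaches a limit of the assay, > 100000 nM; this is the limit of > 100000 nM in this assay, at which 1 of the 2 values shown sits. Among the measured compounds shown here, the one measured step, an at least 1.4-fold lower number from compound 1 to compound 2 (0.16 log units; that floor lies within the scatter), therefore cannot be told apart from the scatter. Compound 3 `CN(C)C(=O)c1cc(CCCOc2ccc(-c3noc(C(F)(F)F)n3)cc2C(F)(F)F)on1` changes compound 2 at a different place: trifluoromethyl in place of methoxy on an aromatic carbon. For the measured compounds named here, no measured step concerns that aromatic carbon; the step at the carbonyl carbon carries no information about it. Going by the values given here, what is known is only that one exchange elsewhere in the molecule left the read-out within the scatter. On that basis the account expects no change beyond the scatter in this assay, and the estimate for compound 3 is 60000 nM with a range from 20000 nM to 150000 nM. The step this means, a 1.1-fold lower number from compound 2 to compound 3 (0.05 log units; within the scatter), is expected to stay within the scatter, though the chance remains that compound 3 again returns only a limit.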

Compound 3, half-maximal cytotoxic concentration: 19200 nM
The estimate for compound 3 lay 3.1-fold (0.49 log units) above the measured number, and the stated range ends above it.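

Among these compounds, the aromatic carbon that the earlier compounds left unchanged does register in this assay: trifluoromethyl in place of methoxy gives a 3.5-fold lower number from compound 2 to compound 3 (0.55 log units; beyond the scatter), a modest step, but one beyond the scatter, whereas the exchange at the carbonyl carbon could not be told apart from it. Among the compounds shown here, on this read-out, the lower number means higher toxicity in this test, so this position is not silent, and compound 3 at 19200 nM is the first compound whose number stands clear of another's. This rests on a single pair of compounds, and nothing shown gives a cause for the step.

The compounds shown leave open whether the step follows from the entry of trifluoromethyl or from the loss of methoxy, and how a chlorine atom, a hydroxyl group or an amine on the same aromatic carbon would read in this assay. They also leave open whether the same exchange would give a step of similar size with ethoxy rather than dimethylamino on the carbonyl carbon.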